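A few compounds are considered here, and "the series" means these few. Any claim that something is new, unique, unknown or untested is made for them only; others in the source may bear on it.

Working notes on the series in a functional assay on MKN-74 cells (Homo sapiens) for antiproliferative activity, with a stated time of 24 h; a lower number here means a stronger inhibitor, a higher number a weaker inhibitor.

Three close analogues sharing one core have been run. Compound 1 `NC(=O)c1c(NC(=O)c2ccccc2)sc2c1CCN(C(=S)Nc1ccccc1Cl)C2` gives 11800 nM in this assay. Compound 2 `NC(=O)c1c(NC(=O)c2ccccc2Br)sc2c1CCN(C(=S)Nc1ccccc1Cl)C2`, which carries bromo in place of hydrogen on the benzamide ring, gives 12900 nM. Compound 3 `Cc1ccccc1C(=O)Nc1sc2c(c1C(N)=O)CCN(C(=S)Nc1ccccc1Cl)C2`, with methyl at that carbon instead, gives 11000 nM. The steps between them are all small: a 1.1-fold higher number from compound 1 to compound 2 (0.04 log units; within the scatter), a 1.1-fold lower number from compound 1 to compound 3 (0.03 log units; within the scatter) and a 1.2-fold lower number from compound 2 to compound 3 (0.07 log units; within the scatter). Compound 2 therefore stands nowhere apart from the other two; its steps to compound 1 and to compound 3 both sit inside the scatter, so the three numbers cannot be told apart.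

The next compound, compound 4 `NC(=O)c1c(NC(=O)c2ccccc2Br)sc2c1CCN(C(=S)Nc1ccccc1Br)C2`, differs from compound 2 by bromo in place of chloro on an aromatic carbon. Among the compounds with values here, no measured step touches this ring directly. Within the data shown here, the steps that bear on it are the substituent swaps on the other aromatic ring, the steps from compound 1 to compound 2 and from compound 2 to compound 3, and both stayed within the scatter, so single-atom changes on an aromatic carbon have so far not moved this assay.

On that basis compound 4 is expected to give 12500 nM, estimated range 6500 nM to 24000 nM, and the step from compound 2 is expected to be a 1.0-fold lower number from compound 2 to compound 4 (0.01 log units; within the scatter), no change beyond the scatter.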

Compound 4, half-maximal inhibitory concentration: 13700 nM
Compound 4: middle estimate off by 1.1-fold (0.04 log units), on the low side, within the range that was stated.
By their numbers in this assay, from the lowest: compounds 3, 1, 2 and 4 (each within the scatter of the next).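

Within the data shown here, compound 4 supplies the only measured step on the ring carrying the (2-chlorophenyl)amino group, since the earlier steps all lie on the other aromatic ring, and in this assay bromo in place of chloro there gives a 1.1-fold higher number from compound 2 to compound 4 (0.03 log units; within the scatter). This aromatic carbon, ortho to a large group, therefore accepts one halogen in place of the other without a change beyond the scatter, and the absence of a measurable shift now holds on both aromatic rings for the single-atom changes shown, with no compound going against it. Nothing available explains why these numbers stay so close together.

What the compounds shown leave open is whether hydrogen, an amine or a carboxylic acid at this same carbon would move the number beyond the scatter, since only chloro and bromo stand here so far. As far as these compounds go, it also remains open whether any change in this assay can move the series at all, for instance a nitrile in place of the carboxamide on the shared core or a longer chain in place of the 2-bromophenyl group.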